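This account rests on a few compounds, and the source may have more. Where it says the series, first, only, none or still open, it means among the compounds named here.

Compound 1 `Cc1nc(-c2ccc(F)cc2)ccc1C(=O)Nc1ccc2ccn(C)c2c1`, a limit only, gives < 6.5 in an in vitro functional assay on 1321-N1 cells for antagonist activity at transient receptor potential cation channel subfamily V member 1 (Homo sapiens), read by FLIPR and calcium flux; a lower number here means a less potent compound, a higher number a more potent compound, by a factor of ten per unit of this negative logarithm.
Compound 2 `N#Cc1ccc(C(=O)Nc2ccc3cccnc3c2)cn1`, a limit only, gives < 6.7 in this assay.
Compound 3 `O=C(Nc1ccc2cccnc2c1)c1ccc(-c2ccc(C(F)(F)F)cc2)nc1` gives 7.3 in this assay.

Compound 2 stands at a limit of the assay, not at a measured number; the value reported for it, (the limit of < 6.7 in this assay, at which 1 of the 3 values shown sits), says only that its potency falls short of what the assay can resolve. Compound 1 sits at the other limit shown, (the limit of < 6.5 in this assay, at which 1 of the 3 values shown sits). For the measured compounds named here, compound 3 is the one compound of the three with a real number.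

Compound 4 `O=C(Nc1ccc2cccnc2c1)c1ccc(-c2cccc(F)c2)nc1` is compound 2 with one replacement: 3-fluorophenyl in place of cyano on an aromatic carbon. Going by the values given here, no measured pair of neighbours tells directly what this change does, so the expectation rests on compound 3, which likewise carries a six-membered aromatic ring of carbon only in place of the cyano and gives 7.3. Compound 4 is therefore expected to gain clearly beyond the scatter, with a number at least 0.40 log units higher from compound 2 to compound 4 (beyond the scatter) estimated as the step. For compound 4 the expected value is 7.1, between 6.5 and 7.7.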

Compound 4, negative logarithm of the antagonist equilibrium constant: 8.6
Compound 4: the middle estimate sits 1.50 log units below what was measured, outside the stated range (above it).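

For the compounds shown here, replacing the cyano with 3-fluorophenyl on the aromatic carbon next to the ring nitrogen gives a number at least 1.90 log units higher from compound 2 to compound 4 (beyond the scatter), the first direct reading of a change at this position in this assay. From the compounds shown here alone, the full size of this step stays unknown, since compound 2 holds only a limit: the limit of < 6.7 in this assay, at which 1 of the 4 values shown sits. Compound 3, whose carbon-only aromatic ring carries trifluoromethyl, gives 7.3, while compound 4 gives 8.6, so having such a ring at this position does not settle the number; what that ring carries goes with a different value.

Going by these compounds, whether the gain belongs to the ring alone or also to its fluorine remains open, and a plain phenyl would bear on that. Also open, on these data alone, is what a non-aromatic group on this carbon, such as an amine or a morpholine, would give.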